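The compounds below may be only part of what the source reports. "The series", "measured", "known", "first", "only" and "open" are said of these compounds alone.

In a functional assay on MCF7 cells (Homo sapiens) for cytotoxicity, read by MTT assay, with a stated time of 72 h (on this read-out higher numbers stand for weaker inhibition and lower numbers for stronger inhibition), compound 1 `O=C(N/N=C/c1ccc(F)cc1Cl)Nc1cc2c(Nc3ccc(F)c(Cl)c3)ncnc2cc1O[C@H]1CCOC1` gives 32200 nM and compound 2 `O=C(N/N=C/c1ccc(O)c(Br)c1)Nc1cc2c(Nc3ccc(F)c(Cl)c3)ncnc2cc1O[C@H]1CCOC1` gives 2690 nM while compound 3 `CCN(CC)c1ccc(/C=N/NC(=O)Nc2cc3c(Nc4ccc(F)c(Cl)c4)ncnc3cc2O[C@H]2CCOC2)c(O)c1` gives 15600 nM as the middle of the three numbers. Compound 4 `O=C(N/N=C/c1ccc(O)cc1)Nc1cc2c(Nc3ccc(F)c(Cl)c3)ncnc2cc1O[C@H]1CCOC1` differs from compound 3 by 4-hydroxyphenyl in place of 4-(diethylamino)-2-hydroxyphenyl on a carbon with a double bond to nitrogen and has not yet been measured. The nearest evidence is the modest step of a 5.8-fold higher number from compound 2 to compound 3 (0.76 log units; beyond the scatter) from 3-bromo-4-hydroxyphenyl to 4-(diethylamino)-2-hydroxyphenyl, beside the large step of a 12-fold lower number from compound 1 to compound 2 (1.08 log units; beyond the scatter) and the modest step of a 2.1-fold lower number from compound 1 to compound 3 (0.31 log units; beyond the scatter) among the same compounds. Within the data shown here, no measured compound carries 4-hydroxyphenyl itself, so the size remains uncertain. A modest downward move in this assay is expected, with a 2.2-fold lower number from compound 3 to compound 4 (0.35 log units; beyond the scatter) as the estimated step. Compound 4 is expected at 7000 nM with a range from 2000 nM to 25000 nM as estimated here.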

Compound 4, half-maximal inhibitory concentration: 910 nM
The estimate for compound 4 lay 7.7-fold (0.89 log units) above the measured number; measured number below the stated range.
By their numbers in this assay, from the lowest: compound 4; then compound 2; then compound 3; then compound 1.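

In this assay the plain 4-hydroxyphenyl on the carbon with a double bond to nitrogen gives the lowest number of the four compounds, with a 17-fold lower number from compound 3 to compound 4 (1.23 log units; beyond the scatter) and a 35-fold lower number from compound 1 to compound 4 (1.55 log units; beyond the scatter) as its large steps. The bromo is not needed for a low number at this position, since hydrogen in its place gives a 3.0-fold lower number from compound 2 to compound 4 (0.47 log units; beyond the scatter) in a modest step. Nothing measured here accounts for these steps.

The compounds shown do not separate the effect of the diethylamino from that of the 2-hydroxy in compound 3. They also leave open whether a methoxy or an amine in place of the hydroxy of 4-hydroxyphenyl would keep the number of compound 4.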